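From bromo to methoxycarbonyl on the shared core

The compounds below may be only part of what the source reports. "The series", "measured", "known", "first", "only" and "open" are said of these compounds alone.

Measured values in a functional assay on KYSE-450 cells (Homo sapiens) for inhibition, read by MTT assay, with a stated time of 48 h (on this read-out lower numbers stand for stronger inhibition and higher numbers for weaker inhibition), are these:
Compound 1 `COc1ccc(CNc2cc(OC)c(OC)c(OC)c2)cc1Cl` gives 47800 nM
Compound 2 `COc1ccc(CNc2cc(OC)c(OC)c(OC)c2)cc1Br` gives 39800 nM

Among the measured compounds shown here, compound 2 stands within the scatter of compound 1, the only other measured compound. Compound 3 `COC(=O)c1cc(CNc2cc(OC)c(OC)c(OC)c2)ccc1OC` carries methoxycarbonyl in place of bromo on an aromatic carbon. For the measured compounds named here, no measured compound carries methoxycarbonyl, so the evidence is thin. Resting on the only measured step (a 1.2-fold lower number from compound 1 to compound 2 (0.08 log units; within the scatter)), which put bromo in place of chloro, no change beyond the scatter is expected in this assay for this replacement. The expected step is small (a 1.1-fold higher number from compound 2 to compound 3 (0.05 log units; within the scatter)). Compound 3 is estimated at 45000 nM (range 15000 nM to 120000 nM).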

Compound 3, half-maximal inhibitory concentration: 41100 nM
Estimate against measurement, compound 3: 1.1-fold (0.04 log units) above; the range from low to high includes it.
By their numbers in this assay, from the lowest: compounds 2, 3 and 1 (each within the scatter of the next).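

On this aromatic carbon, ortho to a methoxy group, methoxycarbonyl with its 4 heavy atoms and 2 hydrogen-bond acceptors reads the same as either halogen in this assay with a 1.0-fold higher number from compound 2 to compound 3 (0.01 log units; within the scatter) and with a 1.2-fold lower number from compound 1 to compound 3 (0.07 log units; within the scatter) as its two steps. A group larger than bromo and not a halogen at all thus shifts nothing beyond the scatter at this place. Nothing available here accounts for this flat result. On these data alone, whether a carboxylic acid or an amine on this carbon would move the number beyond the scatter stays open. So does whether a longer chain, such as an ethyl ester, would behave like methoxycarbonyl.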